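The compounds below may be only part of what the source reports. "The series", "measured", "known", "first", "only" and "open" are said of these compounds alone.

Measured compounds:
compound 1 `Cc1ccc(-n2cc(C(=O)Nc3cc(F)cc(F)c3)c(=O)c3ccc(N(C)C)nc32)cc1OCCCCCCC[N+]1(C)CCCC1`, in an assay on LX2 cells for inhibition of COL1A1 promoter (Homo sapiens), read by a luciferase reporter, with a stated time of 24 h, tested at 20 uM (a higher number here means a stronger effect of the compound at the concentration tested, a lower number a weaker effect), compound 1 gives 12.7%
compound 2 `CN(C)c1ccc2c(=O)c(C(=O)Nc3cc(F)cc(F)c3)cn(-c3ccc(Cl)c(OCCCCCCC[N+]4(C)CCCC4)c3)c2n1`, in this assay compound 2 gives 51%

Among the measured compounds shown here, of the two numbers, compound 2 stands highest; its nearest neighbour is compound 1, and the single measured step, a number 38.3 percentage points higher from compound 1 to compound 2 (beyond the scatter), separates them. Compound 3 `CN1CC[N+](C)(CCCCCCCOc2cc(-n3cc(C(=O)Nc4cc(F)cc(F)c4)c(=O)c4ccc(N(C)C)nc43)ccc2Cl)CC1` has not been measured. It differs from compound 2 by a group of 8 heavy atoms (6 carbon, 2 nitrogen; one six-membered non-aromatic ring with 2 hetero atoms) in place of a group of 6 heavy atoms (5 carbon, 1 nitrogen; one five-membered non-aromatic ring with 1 hetero atom), on a saturated chain carbon, seven bonds along the chain from an oxygen on an aromatic ring. For the measured compounds named here, no measured step touches this position: the only step known, a number 38.3 percentage points higher from compound 1 to compound 2 (beyond the scatter), concerns a substituent on an aromatic carbon and says nothing about the charged ring at the end of the chain. Going by the values given here, with no comparable step to lean on, the expected change is a number 3 percentage points lower from compound 2 to compound 3 (within the scatter), that is, nothing beyond the scatter in either direction. Compound 3 is therefore estimated at 48%, with a range from 25% to 70%, the width of that range reflecting the absence of any measured precedent for this change.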

Compound 3, a percentage reported as inhibition, at one concentration (the size of the read-out at that concentration, not a potency): 27.5%
Estimate against measurement, compound 3: 20.5 percentage points above; the measured number falls inside the stated range.
By their numbers in this assay, from the lowest: compound 1; then compound 3; then compound 2.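

At the end of the chain, seven bonds along from the oxygen on an aromatic ring, the charged ring proves not to be interchangeable: in this assay, the change to the six-membered non-aromatic ring with 2 hetero atoms gives a number 23.5 percentage points lower from compound 2 to compound 3 (beyond the scatter) on the chloro-bearing compounds. Both groups carry the same net charge, so this step appears with that charge unchanged, while the entering group has 8 heavy atoms and 1 hydrogen-bond acceptor in place of 6 heavy atoms and 0 hydrogen-bond acceptors. Nothing available here accounts for the step.

The two compounds cannot separate ring size from the second ring nitrogen, so a piperidinium or morpholinium ring at the chain end would be needed to tell these apart. As far as these compounds go, it also remains open how either ring behaves on a shorter or longer chain, or with methyl in place of chloro on the aromatic ring.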